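This account rests on a few compounds, and the source may have more. Where it says the series, first, only, none or still open, it means among the compounds named here.

In a functional assay on HeLa cells (Homo sapiens) for inhibition, read by sulforhodamine B assay (a lower number here means a stronger inhibitor, a higher number a weaker inhibitor), compound 1 `COc1cccc(NC2=CC(=O)c3nc4n(c3C2=O)[C@H]2OC[C@@H](O)[C@H]2OC4)c1` gives 4280 nM and compound 3 `CCOc1ccc(NC2=CC(=O)c3nc4n(c3C2=O)[C@H]2OC[C@@H](O)[C@H]2OC4)cc1` gives 3110 nM. For compound 2 `O=C1C=C(NC2CCCCC2)C(=O)c2c1nc1n2[C@H]2OC[C@@H](O)[C@H]2OC1` the read-out is a limit, > 16000 nM, not a number (the limit of > 16000 nM in this assay, at which 1 of the 3 values shown sits). Of the two numbers, compound 3 has the lower one, though the step of a 1.4-fold lower number from compound 1 to compound 3 (0.14 log units; within the scatter) stays within the scatter. Compound 4 `O=C1C=C(Nc2ccccc2F)C(=O)c2c1nc1n2[C@H]2OC[C@@H](O)[C@H]2OC1` differs from compound 3 in one place: 2-fluorophenyl in place of 4-ethoxyphenyl on an amine nitrogen. Going by the values given here, two measured steps bear on this. The step of an at least 5.1-fold lower number from compound 2 to compound 3 (0.71 log units; beyond the scatter), from cyclohexyl to a phenyl group, is large, while the step of a 1.4-fold lower number from compound 1 to compound 3 (0.14 log units; within the scatter), from one phenyl group to another, is small. As compound 4 keeps an aromatic ring on that nitrogen, only a small step of a 1.3-fold higher number from compound 3 to compound 4 (0.11 log units; within the scatter) is expected. Compound 4 is therefore estimated at 4000 nM, between 1500 nM and 12000 nM.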

Compound 4, half-maximal inhibitory concentration: 5120 nM
Beside the measured number, compound 4's estimate is 1.3-fold (0.11 log units) below it; the measured number falls inside the stated range.
By their numbers in this assay, from the lowest: compounds 3, 1 and 4 (each within the scatter of the next). At a limit, above all of these: compound 2.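

In this assay, the 2-fluorophenyl group on the amine nitrogen leaves the number where the alkoxy-bearing phenyl groups had it, with a 1.6-fold higher number from compound 3 to compound 4 (0.22 log units; within the scatter) and a 1.2-fold higher number from compound 1 to compound 4 (0.08 log units; within the scatter). So a fluorine on the phenyl ring serves here as well as an ethoxy or methoxy group, and a third aromatic ring also separates from cyclohexyl, with an at least 3.1-fold lower number from compound 2 to compound 4 (0.49 log units; beyond the scatter). That step rests on a limit for compound 2, not a number: the limit of > 16000 nM in this assay, at which 1 of the 4 values shown sits.

Still open, as far as these compounds go, is whether a pyridine ring or a benzyl group on this nitrogen would stay at this level. From the compounds shown here alone, whether a carboxylic acid or an amine on the phenyl ring would move the number beyond the scatter is also open.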